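Alkyl chain extension across two related cores

The source may hold more compounds than are shown below. What is called first, only, known or untested is meant among the compounds shown, and "the series" means these compounds.

Measured so far in an ADME assay for lipophilicity; a lower number here means a more polar compound, a higher number a more lipophilic compound:
compound 1, `CCOCc1cc(=O)c(O)co1`: compound 1 gives -0.38
compound 2, `CCCOCc1cc(=O)c(O)co1`: compound 2 gives 0.3
compound 3, `CCCn1cccc(O)c1=O`: compound 3 gives 0.69

Compound 1 and compound 2 share a core; compound 3 sits on a second core, and the difference between the two cores is not broken down here. Within the first pair the change is methyl in place of hydrogen on a saturated chain carbon, two bonds along the chain from an oxygen on a saturated carbon, and it gave a number 0.68 log units higher from compound 1 to compound 2 (beyond the scatter). Compound 3 has the highest value of the three measured.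

Compound 4, `CCCCn1cccc(O)c1=O`, is not yet measured. It differs from compound 3 by methyl in place of hydrogen on a saturated chain carbon, three bonds along the chain from an aromatic nitrogen. This is the same kind of change as in the first pair, but the place differs: there the carbon sits two bonds along the chain from an oxygen on a saturated carbon, here three bonds along the chain from an aromatic nitrogen.

Resting on the step of a number 0.68 log units higher from compound 1 to compound 2 (beyond the scatter), a step of similar size is expected, a number 0.56 log units higher from compound 3 to compound 4 (beyond the scatter). Compound 4 is therefore estimated at 1.25, within 0.9 to 1.6.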

Compound 4, distribution coefficient: 1.18
Estimate against measurement, compound 4: 0.07 log units above; the measured number falls inside the stated range.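

In this assay, the added methyl gave a number 0.49 log units higher from compound 3 to compound 4 (beyond the scatter), and the earlier step on the other core agrees with it: the same change on two cores in this assay, a number 0.68 log units higher (beyond the scatter) from compound 1 to compound 2 and a number 0.49 log units higher (beyond the scatter) from compound 3 to compound 4, 0.19 log units apart, within the scatter of two such steps. On these two cores, the change therefore carried over in the same direction and with a similar size. This rests on a single pair per core, with the change in a different place on each chain, so it does not show that the step would hold on other cores or in other places.

Still open, as far as these compounds go, is whether the same step follows on a longer chain such as pentyl. Also open, from the compounds shown here alone, is how an amine or a carboxylic acid on the chain would read in this assay.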